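Methyl for trifluoromethyl on the aryl ring of a succinimide amide

The source may report more compounds than this note shows. Statements on the series, on what has been measured and on what is new or still open speak of the compounds shown alone.

Compound 1 `CCC(C(=O)N1CCN(c2cccc(OC)c2)CC1)N1C(=O)CCC1=O`: 0%
Compound 2 `CCC(C(=O)N1CCN(c2ccccc2F)CC1)N1C(=O)CCC1=O`: 100%
Compound 3 `CCC(C(=O)N1CCN(c2cccc(C(F)(F)F)c2)CC1)N1C(=O)CCC1=O`: 50%

In a functional assay on the whole organism (strain Swiss) with Mus musculus as the target, in the maximal electroshock model, with a stated time of 0.5 h, at a dose of 300 mg/kg by the intraperitoneal route (a higher number here means a stronger effect of the compound at the dose given, a lower number a weaker effect), compound 3 stands second of the three measured values, half-way between compound 1 and compound 2. Compound 4 `CCC(C(=O)N1CCN(c2cccc(C)c2)CC1)N1C(=O)CCC1=O` differs from it by methyl in place of trifluoromethyl on an aromatic carbon. Going by the values given here, no measured step swaps these two groups, so the steps that bear on it only show how strongly the aryl substituent moves this read-out: a number 100 percentage points higher from compound 1 to compound 2 (beyond the scatter) and a number 50 percentage points higher from compound 1 to compound 3 (beyond the scatter). Because compound 1 gives 0%, a group of that kind at this place can also leave the compound inactive. Compound 4 is therefore expected to lie below compound 3, with wide uncertainty: an estimated 25%, from 0% to 75%. This estimate means an expected step of a number 25 percentage points lower from compound 3 to compound 4 (beyond the scatter).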

Compound 4, a percentage reported as activity, at one dose (the size of the read-out at that dose, not a potency): 100%
For compound 4 the middle estimate is 75 percentage points below the measured one; measured number outside the range, above it.
By their numbers in this assay, from the lowest: compound 1; then compound 3; then compounds 2 and 4 (each within the scatter of the next).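

In this assay, methyl in place of trifluoromethyl on this aromatic carbon gives a number 50 percentage points higher from compound 3 to compound 4 (beyond the scatter) and shows that a group without fluorine can carry the full read-out at this place. Methyl in place of methoxy gives a number 100 percentage points higher from compound 1 to compound 4 (beyond the scatter), and 3-methylphenyl in place of 2-fluorophenyl gives no change at the digits printed from compound 2 to compound 4 (within the scatter) as its result. No measurement offers an explanation for these differences. Going by these compounds, what a chlorine atom or an ethyl group would give on this aromatic carbon stays open, as does whether compound 2 and compound 4 would still match at a lower dose.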